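Amide aryl variation on a shared azo-indole core

This account rests on a few compounds, and the source may have more. Where it says the series, first, only, none or still open, it means among the compounds named here.

Measured in a functional assay on HCT-116 cells (Homo sapiens) for inhibition, read by MTT assay, with a stated time of 72 h; a higher number here means a weaker inhibitor, a lower number a stronger inhibitor:
compound 1 `Cc1cccc(NC(=O)c2ccc(/N=N\c3c[nH]c4ccccc34)cc2)c1C` 272000 nM
compound 2 `O=C(Nc1ccccc1[N+](=O)[O-])c1ccc(/N=N\c2c[nH]c3ccccc23)cc1` 208000 nM
compound 3 `O=C(Nc1cccc(Cl)c1)c1ccc(/N=N\c2c[nH]c3ccccc23)cc1` 80000 nM

Compound 3 gives the lowest number of the three: a 3.4-fold lower number from compound 1 to compound 3 (0.53 log units; beyond the scatter) and a 2.6-fold lower number from compound 2 to compound 3 (0.41 log units; beyond the scatter), both beyond the scatter, whereas a 1.3-fold lower number from compound 1 to compound 2 (0.12 log units; within the scatter) stays within it. Compound 4 `Cc1cccc(NC(=O)c2ccc(/N=N\c3c[nH]c4ccccc34)cc2)c1` differs from compound 3 by methyl in place of chloro on an aromatic carbon. Within the data shown here, no measured pair isolates this exchange; the nearest guide is compound 1, which carries a methyl at the same place together with a second methyl, and there the number sits far higher than for compound 3. The step is therefore expected to raise the number, by a 1.9-fold higher number from compound 3 to compound 4 (0.27 log units; within the scatter), though with wide uncertainty. Compound 4 is estimated at 150000 nM in this assay, range 70000 nM to 350000 nM.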

Compound 4, half-maximal inhibitory concentration: 98900 nM
For compound 4 the middle estimate is 1.5-fold (0.18 log units) above the measured one; measured number inside the range.
By their numbers in this assay, from the lowest: compounds 3 and 4 (each within the scatter of the next); then compounds 2 and 1 (each within the scatter of the next).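

In this assay, chloro and methyl on this aromatic carbon are not told apart (a 1.2-fold higher number from compound 3 to compound 4 (0.09 log units; within the scatter)), so the result for the 3-chlorophenyl group does not depend on chloro. Removing the second methyl of compound 1 does count (a 2.8-fold lower number from compound 1 to compound 4 (0.44 log units; beyond the scatter)), and the 3-methylphenyl group also stands clear of the 2-nitrophenyl group (a 2.1-fold lower number from compound 2 to compound 4 (0.32 log units; beyond the scatter)). Nothing available explains these steps. Going by these compounds, whether an amine, a methoxy or a carboxylic acid at this place would keep the number at this level stays open, as does the plain phenyl group.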